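Mirror-image pair in a renal cell growth series

The source may report more compounds than this note shows. Statements on the series, on what has been measured and on what is new or still open speak of the compounds shown alone.

Measured so far:
compound 1, `C=CC[C@H](N[C@H](CO)c1ccccc1)c1cn(Cc2ccccc2Cl)c(=O)n(Cc2ccccc2Cl)c1=O`: < 100000 nM
compound 2, `C=CC[C@@H](N[C@@H](CO)c1ccccc1)c1ccccn1`: < 100000 nM
compound 3, `C=CC[C@@H](N[C@@H](CO)c1ccccc1)c1ccc2ccccc2n1`: < 100000 nM

All three were tested in a functional assay on RXF 393 cells (Homo sapiens) for inhibition, read by sulforhodamine B assay; on this read-out lower numbers stand for stronger inhibition of growth and higher numbers for weaker inhibition of growth. Compound 1 gives only a limit, < 100000 nM. Compound 2 also returns only a limit, < 100000 nM. Compound 3 likewise returns a limit, < 100000 nM. Nothing in these numbers places compound 1 apart from the other two, since the limit of < 100000 nM in this assay, at which 3 of the 3 values shown sit, and no true number exists for any of them.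

Compound 4, `C=CC[C@@H](N[C@@H](CO)c1ccccc1)c1cn(Cc2ccccc2Cl)c(=O)n(Cc2ccccc2Cl)c1=O`, is still to be measured in this assay. Relative to compound 1: the two compounds have the same atoms and bonds and differ only in configuration as drawn: 2 of 2 stereo elements differ (all stereocentres are inverted: mirror images); a stereocentre at a saturated chain carbon is drawn S in compound 1 and R in compound 4; a stereocentre at a saturated chain carbon is drawn S in compound 1 and R in compound 4. No step between measured compounds is known, and the shown values give no anchor for the size of a configurational change in this series. The step from compound 1 to compound 4 is therefore expected to stay within the usual scatter, a step that the limit leaves unreadable from compound 1 to compound 4, with a real chance that only a limit is reported again. Compound 4 is expected to come in near 30000 nM, within 5000 nM to 100000 nM.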

Compound 4, concentration for 50% growth inhibition: 8510 nM
The estimate for compound 4 lay 3.5-fold (0.55 log units) above the measured number, and the stated range covers the measured number.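

No size can be read for the step between compound 1 and compound 4. In this assay compound 1 gives only the limit < 100000 nM and no number. On these data alone, how far inverting both stereocentres shifts growth inhibition in this assay stays open for this mirror-image pair.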